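Dropping a methyl and swapping halogen on the aryl tail

A few compounds are considered here, and "the series" means these few. Any claim that something is new, unique, unknown or untested is made for them only; others in the source may bear on it.

Values measured so far in a functional assay on SK-OV-3 cells (Homo sapiens) for cytotoxicity; a lower number here means a stronger inhibitor, a higher number a weaker inhibitor

Compound 1 `C=C/C=C\[C@H](C)[C@H](OC(N)=O)[C@@H](C)[C@H](O)[C@@H](C)C/C(C)=C\[C@H](C)[C@@H](O)[C@@H](C)/C=C\CCc1ccc(C)c(F)c1` gives 1000 nM
Compound 2 `C=C/C=C\[C@H](C)[C@H](OC(N)=O)[C@@H](C)[C@H](O)[C@@H](C)C/C(C)=C\[C@H](C)[C@@H](O)[C@@H](C)/C=C\CCc1cccc(F)c1` gives 400 nM
Compound 3 `C=C/C=C\[C@H](C)[C@H](OC(N)=O)[C@@H](C)[C@H](O)[C@@H](C)C/C(C)=C\[C@H](C)[C@@H](O)[C@@H](C)/C=C\CCc1cccc(O)c1C` gives 270 nM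

Compound 1 stands highest of the three, making it the weakest inhibitor measured, and both steps away from it lie beyond the scatter. The next compound, compound 4 `C=C/C=C\[C@H](C)[C@H](OC(N)=O)[C@@H](C)[C@H](O)[C@@H](C)C/C(C)=C\[C@H](C)[C@@H](O)[C@@H](C)/C=C\CCc1cccc(Cl)c1`, has not yet been measured. Its change from compound 1 is 3-chlorophenyl in place of 3-fluoro-4-methylphenyl on a saturated chain carbon, two bonds along the chain from a double-bonded chain carbon, with 3-chlorophenyl in place of 3-fluoro-4-methylphenyl on a saturated chain carbon, two bonds along the chain from a double-bonded chain carbon.

For the measured compounds named here, the closest precedent is a 2.5-fold lower number from compound 1 to compound 2 (0.40 log units; beyond the scatter), where hydrogen replaces methyl on an aromatic carbon and 3-fluorophenyl results. Replacing the aryl group outright gave a 3.7-fold lower number from compound 1 to compound 3 (0.57 log units; beyond the scatter), while a 1.5-fold lower number from compound 2 to compound 3 (0.17 log units; within the scatter) separates the two products. Going by the values given here, no measured compound carries chlorine, so that part of the change remains untested.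

A modest lowering is therefore expected, and the estimated step is a 2.9-fold lower number from compound 1 to compound 4 (0.46 log units; beyond the scatter). Compound 4 is expected at 350 nM, with an estimated range from 130 nM to 900 nM.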

Compound 4, half-maximal inhibitory concentration: 380 nM
Compound 4: middle estimate off by 1.1-fold (0.04 log units), on the low side, within the range that was stated.
By their numbers in this assay, from the lowest: compounds 3, 4 and 2 (each within the scatter of the next); then compound 1.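

In this assay, the 3-chlorophenyl tail gives a 2.6-fold lower number from compound 1 to compound 4 (0.42 log units; beyond the scatter) and so shows that the drop from compound 1 does not require fluorine on the aromatic ring. Chloro in place of fluoro gives a 1.1-fold lower number from compound 2 to compound 4 (0.02 log units; within the scatter) and leaves no difference that can be read between the two halogens at this position. The step of a 1.4-fold higher number from compound 3 to compound 4 (0.15 log units; within the scatter) is also within the scatter, so compounds 2, 3 and 4 cannot be ordered, even though the 3-hydroxy-2-methylphenyl tail of compound 3 differs from the two halogenated tails. No measurement shown explains these steps.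

The compounds shown leave open whether bromine, a methoxy group or an amine on the aromatic ring would separate from this cluster. They also leave open how a longer chain to the ring would compare.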